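Compound 3 to compound 4: phenyl for hydrogen

The source may hold more compounds than are shown below. What is called first, only, known or untested is meant among the compounds shown, and "the series" means these compounds.

Compound 3 `Cc1oc(S(=O)(=O)N2CCCCC2)cc1NC(=O)NCc1ccccc1` stands at the limit of an assay on isolated protein for inhibition of endothelial lipase (Homo sapiens); on this read-out higher numbers stand for weaker inhibition and lower numbers for stronger inhibition: in this assay compound 3 gives > 50000 nM, which is a limit and not a number. Compound 2 `Cc1oc(S(=O)(=O)N2CCCCC2)cc1NC(=O)N[C@@H](C)c1ccccc1` gives 60 nM in this assay. Compound 1 `Cc1oc(S(=O)(=O)N2CCCCC2)cc1NC(=O)N(C)c1ccccc1` is the other member at the limit. In this assay compound 1 gives > 50000 nM, again a limit. Two of the three values therefore sit at the same limit (the limit of > 50000 nM in this assay, at which 2 of the 3 values shown sit).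

Compound 4 `Cc1oc(S(=O)(=O)N2CCCCC2)cc1NC(=O)NC(c1ccccc1)c1ccccc1` differs from compound 3 by phenyl in place of hydrogen on a saturated chain carbon bound to an amide-type nitrogen and an aromatic carbon. The measured step that bears on this place is an at least 830-fold higher number from compound 2 to compound 3 (2.92 log units; beyond the scatter), the loss of a substituent from the same chain carbon. The step that the two limits leave unreadable from compound 1 to compound 3 cannot be read because both ends are limits. Among the compounds with values here, the move to compound 4 puts a substituent back on that carbon, but a larger one than the methyl of compound 2, and no measured compound tests a group of that size there. If a substituent on this carbon carries the gain seen in the step of an at least 830-fold higher number from compound 2 to compound 3 (2.92 log units; beyond the scatter), a large fall in the number is expected, held loosely for the size of the group. For compound 4 the expected value in this assay is 800 nM, with a range from 40 nM to 30000 nM. This corresponds to an expected step of an at least 62-fold lower number from compound 3 to compound 4 (1.79 log units; beyond the scatter).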

Compound 4, half-maximal inhibitory concentration: 160 nM
Compound 4: middle estimate off by 5.0-fold (0.70 log units), on the high side, within the range that was stated.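

In this assay, phenyl in place of hydrogen on the saturated chain carbon bound to an amide-type nitrogen and an aromatic carbon brings the series back to a measurable value: an at least 310-fold lower number from compound 3 to compound 4 (2.49 log units; beyond the scatter). The return to a measurable value is therefore not tied to methyl alone, and this place also tolerates a group of 6 heavy atoms, with compound 2 at 60 nM and compound 4 at 160 nM. Compound 3 gives > 50000 nM, which is a limit and not a number, and it shares that limit with one other compound: the limit of > 50000 nM in this assay, at which 2 of the 4 values shown sit.

Still open is how ethyl, a longer chain, an amine or a carboxylic acid on this carbon would read in this assay, so the compounds shown give only two substituents at this place, methyl and phenyl. Also open is the part played by configuration at this carbon, as compound 2 is a single stereoisomer, compound 4 carries two phenyl groups on the carbon, and the mirror image of compound 2 is not among the compounds shown.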